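The source may hold more compounds than are shown below. What is called first, only, known or untested is meant among the compounds shown, and "the series" means these compounds.

Two compounds share a core in which a pyridine-bearing heterocycle is joined through a sulfur-linked acetyl hydrazone to a substituted benzene ring, and both have been tested in a functional assay on HepG2 cells (Homo sapiens) for cytotoxicity, read by MTT assay, with a stated time of 48 h; on this read-out lower numbers stand for stronger inhibition and higher numbers for weaker inhibition. Compound 1 `O=C(CSc1nnc(-c2ccncc2)o1)N/N=C/c1ccc(Br)cc1` gives 18600 nM. Compound 2 `COc1ccc(/C=N/NC(=O)CSc2nnc(-c3ccncc3)o2)cc1` gives 15800 nM. For the measured compounds named here, the only step measured so far, a 1.2-fold lower number from compound 1 to compound 2 (0.07 log units; within the scatter), is therefore a change that the scatter of this assay cannot separate, and compound 2 stands within that scatter of compound 1, the only other number available.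

Compound 3 `O=C(CSc1nnc(-c2ccncc2)o1)N/N=C/c1ccccc1O` is not yet measured. It differs from compound 2 by 2-hydroxyphenyl in place of 4-methoxyphenyl on a carbon with a double bond to nitrogen. Going by the values given here, no measured step touches this change: the one known step swaps one group for another at a different location on the same ring, and it was itself within the scatter. There is thus no evidence pointing in either direction, and the expectation for compound 3 in this assay is a number close to that of compound 2, with a step of a 1.1-fold lower number from compound 2 to compound 3 (0.02 log units; within the scatter) that is expected to stay within the scatter. The estimate for compound 3 is 15000 nM, expected to fall between 6000 nM and 40000 nM.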

Compound 3, half-maximal inhibitory concentration: 3510 nM
Compound 3: middle estimate off by 4.3-fold (0.63 log units), on the high side, and the stated range ends above it.
By their numbers in this assay, from the lowest: compound 3; then compounds 2 and 1 (each within the scatter of the next).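

On the carbon with a double bond to nitrogen, the choice of aryl group can clearly change the number in this assay: 2-hydroxyphenyl in place of 4-methoxyphenyl gives a 4.5-fold lower number from compound 2 to compound 3 (0.65 log units; beyond the scatter) and 2-hydroxyphenyl in place of 4-bromophenyl gives a 5.3-fold lower number from compound 1 to compound 3 (0.72 log units; beyond the scatter) on the same read-out. For the compounds shown here, the earlier swap between 4-bromophenyl and 4-methoxyphenyl stayed within the scatter, so this is the first sign that the position responds to a change, and compound 3 now has the lowest number of the three, with both of its steps beyond the scatter. In the counts, the entering 2-hydroxyphenyl has 1 hydrogen-bond donor and the departing 4-methoxyphenyl has 0, but this is only a structural difference that goes along with the step, not a demonstrated reason for it.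

Going by these compounds, the step changes both the group and its place on the ring, so it remains open whether the hydroxy group or its place matters, a question that 4-hydroxyphenyl and 2-methoxyphenyl would help separate, while 2-aminophenyl would test a different group in the same place. What lies behind the lower number of compound 3 also remains open, as nothing available here offers an explanation for it.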